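Working notes: replacing 2-carboxypiperidin-1-yl in compound 3

The source may report more compounds than this note shows. Statements on the series, on what has been measured and on what is new or still open speak of the compounds shown alone.

Values in a functional assay on HepG2 cells (Homo sapiens) for antiproliferative activity, read by CCK-8 assay, with a stated time of 48 h (on this read-out lower numbers stand for stronger inhibition and higher numbers for weaker inhibition), for the measured compounds
compound 1 `COc1ccc(/C=C\c2cc(OC)c(OC)c(OC)c2)cc1OCc1ccc(CNC(C)(C)C(=O)O)cc1` gives 6500 nM
compound 2 `COc1ccc(/C=C\c2cc(OC)c(OC)c(OC)c2)cc1OCc1ccc(CN2CCCC[C@H]2C(=O)O)cc1` gives > 10000 nM
compound 3 `COc1ccc(/C=C\c2cc(OC)c(OC)c(OC)c2)cc1OCc1ccc(CN2CCCCC2C(=O)O)cc1` gives 3100 nM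

Compound 2 is reported with > 10000 nM as a limit of the assay and not as a number. Compound 3 with 3100 nM holds the lowest of the two actual numbers, and compound 1 with 6500 nM holds the other.

In compound 4 `COc1ccc(/C=C\c2cc(OC)c(OC)c(OC)c2)cc1OCc1ccc(CN[C@H](C(=O)O)[C@H](C)O)cc1` the (1-carboxy-2-hydroxypropyl)amino group stands in place of 2-carboxypiperidin-1-yl on a saturated chain carbon bound to an aromatic carbon, counted as (1-carboxy-2-hydroxypropyl)amino in place of 2-carboxypiperidin-1-yl on a saturated chain carbon bound to an aromatic carbon with no ring in the entering group.

The closest measured comparison is a 2.1-fold lower number from compound 1 to compound 3 (0.32 log units; beyond the scatter) and its starting group, (1-carboxy-1-methylethyl)amino, has no ring either. The step of an at least 1.5-fold higher number from compound 1 to compound 2 (0.18 log units; that floor lies within the scatter) rests on a limit and adds little. The step of an at least 3.2-fold lower number from compound 2 to compound 3 (0.50 log units; beyond the scatter) goes with the fact that one of compounds 2 and 3 is drawn with a defined configuration and the other without, at the place where they differ and this argues for a wide range here, where defined stereocentres enter. Compound 1 with 6500 nM is therefore the best guide to the new group. The change expected in this assay is a 1.9-fold higher number from compound 3 to compound 4 (0.29 log units; within the scatter) and would be modest, toward a higher number. From the compounds shown here alone, the estimate for compound 4 is 6000 nM with an expected range from 2500 nM to 14000 nM and the measurement remains open.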

Compound 4, half-maximal inhibitory concentration: > 10000 nM
Compound 4: a limit, no number; the forecaster's own chance of this, stated with the estimate: 25%; middle value at least 1.6-fold (0.22 log units) from the limit.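

In this assay compound 4 gives > 10000 nM as a limit of the assay and not as a number. The step away from 2-carboxypiperidin-1-yl (an at least 3.2-fold higher number from compound 3 to compound 4 (0.50 log units; beyond the scatter)) shows that (1-carboxy-2-hydroxypropyl)amino, on a saturated chain carbon bound to an aromatic carbon, joins (1-carboxy-1-methylethyl)amino as a second group without a ring that sits on the higher side of compound 3, while compound 2, which carries the ring, goes against any simple link between the ring and a lower number. The step between the two groups without a ring (an at least 1.5-fold higher number from compound 1 to compound 4 (0.18 log units; that floor lies within the scatter)) has a floor within the scatter and gives them no order, and the step between compound 2 and compound 4 cannot be read: the limit of > 10000 nM in this assay, at which 2 of the 4 values shown sit.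

From the compounds shown here alone, what a methyl ester in place of the carboxylic acid would give at this place remains open. The compounds shown also do not separate the loss of the ring from the entry of two defined stereocentres, and configuration is already an unsettled matter at this place: the fact that one of compounds 2 and 3 is drawn with a defined configuration and the other without, at the place where they differ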